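Swapping a Triazole Arm for a Dihydroxypropyl Amide

This account rests on a few compounds, and the source may have more. Where it says the series, first, only, none or still open, it means among the compounds named here.

Compound 1 `Cn1ncc(Cl)c1-c1cc(C(=O)N[C@@H]2CN[C@H](CCn3cncn3)C[C@H]2c2ccc(Cl)c(Cl)c2)oc1Cl` is tested in a functional assay on HCT-116 cells (Homo sapiens) for antiproliferative activity, read by sulforhodamine B assay, with a stated time of 72 h (a lower number here means a stronger inhibitor, a higher number a weaker inhibitor), where compound 1 gives 560 nM. Two close relatives sit near it: compound 2 `CC(=O)NCC[C@@H]1C[C@@H](c2ccc(F)c(F)c2)[C@H](NC(=O)c2cc(-c3c(Cl)cnn3C)c(Cl)o2)CN1` gives 920 nM and compound 3 `CC(=O)OCC[C@@H]1C[C@@H](c2ccc(F)c(F)c2)[C@H](NC(=O)c2cc(-c3c(Cl)cnn3C)c(Cl)o2)CN1` gives 690 nM. The number for compound 1 is the lowest of the three, yet the gaps to compound 3 and to compound 2 both lie within the scatter, so no ordering among them can be read.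

The unmeasured compound 4 `Cn1ncc(Cl)c1-c1cc(C(=O)N[C@@H]2CN[C@H](CC(=O)NCC(O)CO)C[C@H]2c2ccc(Cl)c(Cl)c2)oc1Cl` differs from compound 1 at the chain hanging from the shared core: (2,3-dihydroxypropyl)carbamoyl in place of (1H-1,2,4-triazol-1-yl)methyl on a saturated chain carbon bound to a saturated ring carbon.

Going by the values given here, only one measured step alters that chain end: a 1.3-fold lower number from compound 2 to compound 3 (0.12 log units; within the scatter), a swap that left the number essentially unchanged. Among the compounds with values here, that hint points to a small effect of changes at the chain end, but the change from compound 1 to compound 4 is larger than the one in that step, so some movement beyond the scatter cannot be ruled out. For compound 4 the expected step is a 1.4-fold higher number from compound 1 to compound 4 (0.15 log units; within the scatter) in this assay. Compound 4 is therefore estimated at 800 nM, with a range from 350 nM to 2000 nM.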

Compound 4, half-maximal inhibitory concentration: 7090 nM
The estimate for compound 4 lay 8.9-fold (0.95 log units) below the measured number, and the stated range ends below it.
By their numbers in this assay, from the lowest: compounds 1, 3 and 2 (each within the scatter of the next); then compound 4.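

In this assay, placing (2,3-dihydroxypropyl)carbamoyl where (1H-1,2,4-triazol-1-yl)methyl stood gives a 13-fold higher number from compound 1 to compound 4 (1.10 log units; beyond the scatter), so this chain end can strongly weaken the compound. Going by these compounds alone, the only earlier change at this chain end, a 1.3-fold lower number from compound 2 to compound 3 (0.12 log units; within the scatter), gave no sign of that sensitivity. The new group has no ring and 3 hydrogen-bond donors, while the old one has a five-membered aromatic ring and 0 donors, but no measurement here explains the drop in activity.

This single step changes several features at once, so it leaves open whether the loss follows from removing the triazole, adding the amide or adding the two hydroxyl groups. It also leaves open how a simpler end on the same chain, such as a primary amine, a carboxylic acid or a plain N-methyl amide, would behave.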